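The source may hold more compounds than are shown below. What is called first, only, known or untested is meant among the compounds shown, and "the series" means these compounds.

Compound 2 `COC(=O)CCCNC(=O)CN1CN(c2ccccc2)C2(CCN(C(=O)c3ccc(C4CCCCC4)cc3)CC2)C1=O` gives 2500 nM in an assay on HEK293 cells for displacement of a labelled ligand from NPC1-like intracellular cholesterol transporter 1 (Homo sapiens); on this read-out higher numbers stand for weaker inhibition and lower numbers for stronger inhibition. Among the measured compounds shown here, of the two compounds measured so far it holds the higher number; the other, compound 1 `O=C(CN1CN(c2ccccc2)C2(CCN(C(=O)c3ccc(C4CCCCC4)cc3)CC2)C1=O)N1CCC(CO)CC1`, gives 1100 nM in this assay, and the step between them, a 2.3-fold higher number from compound 1 to compound 2 (0.36 log units; beyond the scatter), came with (3-(methoxycarbonyl)propyl)amino in place of 4-(hydroxymethyl)piperidin-1-yl on a carbonyl carbon. Compound 3 `O=C(CN1CN(c2ccccc2)C2(CCN(C(=O)c3ccc(C4CCCCC4)cc3)CC2)C1=O)NCCO` alters compound 2 at that same carbonyl: hydroxy in place of (methoxycarbonyl)methyl on a saturated chain carbon, two bonds along the chain from an amide-type nitrogen, so that the whole group attached there reads (2-hydroxyethyl)amino instead of (3-(methoxycarbonyl)propyl)amino. For the measured compounds named here, only that single measured step bears on the question; it was modest in size and went toward a weaker number when a hydroxymethyl-bearing group was swapped for the (methoxycarbonyl)propyl chain. Compound 3 reinstates a hydroxy on a short chain, though now without a ring, and the step is therefore expected to run the other way by a modest amount, a 1.7-fold lower number from compound 2 to compound 3 (0.22 log units; within the scatter), with the chance that it stays inside the scatter kept in view. Compound 3 is accordingly estimated at 1500 nM, within a range of 600 nM to 4000 nM.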

Compound 3, half-maximal inhibitory concentration: 2000 nM
Compound 3: the middle estimate sits 1.3-fold (0.12 log units) below what was measured; the range from low to high includes it.
By their numbers in this assay, from the lowest: compounds 1, 3 and 2 (each within the scatter of the next, the first and the last beyond it).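

In this assay, replacing the (methoxycarbonyl)methyl part of the chain with hydroxy gives a step that cannot be told from repeat-measurement noise (a 1.3-fold lower number from compound 2 to compound 3 (0.10 log units; within the scatter)), so at this position a chain ending in a methyl ester and the shorter 2-hydroxyethyl group read alike. Setting (2-hydroxyethyl)amino in place of 4-(hydroxymethyl)piperidin-1-yl on the carbonyl carbon also stays inside the scatter (a 1.8-fold higher number from compound 1 to compound 3 (0.26 log units; within the scatter)), which means that a hydroxy-bearing group with no ring reads like the ring-bearing one, and that compound 3 falls in the overlap even though compound 1 and compound 2 are separated beyond the scatter. No measurement at hand gives a reason for these numbers.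

The three groups shown cover only an ester and two alcohols, so it remains open whether a carboxylic acid in place of the methyl ester, or an amine at the end of the chain, would give a step beyond the scatter. A longer chain ending in hydroxy, or a piperidine without the hydroxymethyl group, would also show whether chain length or the ring matters at this carbonyl.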